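Three Close Values and One Untested Swap

The source may hold more compounds than are shown below. What is called first, only, known or untested is meant among the compounds shown, and "the series" means these compounds.

In a functional assay on NCI-H460 cells (Homo sapiens) for antiproliferative activity (on this read-out higher numbers stand for weaker inhibition and lower numbers for stronger inhibition), compound 1 `COc1ccc(N=C2NC(=O)/C(=C\c3ccc(N(C)C)cc3)S2)cc1` gives 1600 nM, compound 2 `Cc1ccc(N=C2NC(=O)/C(=C\c3ccc(N(C)C)cc3)S2)cc1` gives 820 nM, and compound 3 `CN(C)c1ccc(/C=C2/SC(=Nc3ccc(O)cc3)NC2=O)cc1` gives 1080 nM. Compound 3 therefore sits level with the other two, since the data cannot separate these three values from one another.

Compound 4 `CN(C)c1ccc(/C=C2/SC(=Nc3ccccc3Cl)NC2=O)cc1` keeps the core of compound 3 and exchanges one group: 2-chlorophenyl in place of 4-hydroxyphenyl on a double-bonded nitrogen. The closest evidence comes from the three measured steps that alter a small group on this same aromatic ring. They are a 2.0-fold lower number from compound 1 to compound 2 (0.29 log units; within the scatter), a 1.5-fold lower number from compound 1 to compound 3 (0.17 log units; within the scatter) and a 1.3-fold higher number from compound 2 to compound 3 (0.12 log units; within the scatter), and each lies within the scatter. None of them brings in a 2-chlorophenyl, so the data offer no direct guide to this particular exchange, and the range has to stay wide.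

With all three measured steps this small, the expectation in this assay is for no step beyond the scatter and no firm direction. The expected step, a rough estimate, is a 1.1-fold lower number from compound 3 to compound 4 (0.03 log units; within the scatter). The estimated value for compound 4 is 1000 nM. The expected range for compound 4 runs from 350 nM to 2800 nM.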

Compound 4, half-maximal inhibitory concentration: 880 nM
The estimate for compound 4 lay 1.1-fold (0.06 log units) above the measured number, and the stated range covers the measured number.
By their numbers in this assay, from the lowest: compounds 2, 4, 3 and 1 (each within the scatter of the next).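

Among these compounds, compound 4 is the first compound here with 2-chlorophenyl on the double-bonded nitrogen, so it extends the comparison to a ring carrying chlorine, and in this assay the exchange for 4-hydroxyphenyl gives a 1.2-fold lower number from compound 3 to compound 4 (0.09 log units; within the scatter). The comparisons with the other two rings give the same picture, with a 1.1-fold higher number from compound 2 to compound 4 (0.03 log units; within the scatter) and a 1.8-fold lower number from compound 1 to compound 4 (0.26 log units; within the scatter), so the read-out does not separate any of the four compounds, even though 4-hydroxyphenyl has 1 hydrogen-bond donor and 1 hydrogen-bond acceptor while 2-chlorophenyl has 0 hydrogen-bond donors and 0 hydrogen-bond acceptors. Nothing available here offers an explanation for how close these values lie.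

From the compounds shown here alone, it remains open whether any group on this ring can produce a step beyond the scatter, for example an amine, a carboxylic acid or a longer chain such as butoxy in place of the methoxy of compound 1. Going by these compounds, it is also open whether the chlorine of compound 4 matters on its own, a question that a plain phenyl on the double-bonded nitrogen could help to answer.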